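A few compounds are considered here, and "the series" means these few. Any claim that something is new, unique, unknown or untested is made for them only; others in the source may bear on it.

Measured compounds:
compound 1 `Nc1cc(N)c2nc(-c3ccccc3)c(NCc3ccc(Cl)c(Cl)c3)nc2c1`: 9550 nM
compound 2 `CCOC(=O)[C@H](CCC(=O)O)NC(=O)c1ccc(CNc2nc3cc(N)cc(N)c3nc2-c2ccccc2)cc1`: < 100000 nM

For the measured compounds named here, in a functional assay on SK-MEL-2 cells (Homo sapiens) for inhibition, read by sulforhodamine B assay, with a stated time of 48 h (on this read-out higher numbers stand for lower toxicity in this test and lower numbers for higher toxicity in this test), compound 1 gives 9550 nM, the only plain number in the set. For compound 2 this assay returns only a limit, < 100000 nM, so compound 1 stands as the sole measured point against which the next compound can be placed; (the limit of < 100000 nM in this assay, at which 1 of the 2 values shown sits).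

Compound 3 `COc1ccc(CNc2nc3cc(N)cc(N)c3nc2-c2ccccc2)cc1` is not yet measured. Relative to compound 1 the change is 4-methoxyphenyl in place of 3,4-dichlorophenyl on a saturated chain carbon bound to a nitrogen on an aromatic ring, which, cut one bond further out, reads 3,4-dichlorobenzyl to 4-methoxybenzyl.

Going by the values given here, no measured pair that differs in one place is available, so the size of this step has no precedent here. The expectation is a small move toward lower toxicity in this assay, near the edge of the usual scatter, expressed as a 2.1-fold higher number from compound 1 to compound 3 (0.32 log units; beyond the scatter). Compound 3 is therefore expected to give about 20000 nM, with a range from 6000 nM to 60000 nM.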

Compound 3, concentration lethal to 50% of the cells: 57500 nM
Estimate against measurement, compound 3: 2.9-fold (0.46 log units) below; the measured number falls inside the stated range.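

In this assay, for the compounds shown here, 4-methoxyphenyl in place of 3,4-dichlorophenyl on a saturated chain carbon bound to a nitrogen on an aromatic ring gives a 6.0-fold higher number from compound 1 to compound 3 (0.78 log units; beyond the scatter), the first readable step, toward lower toxicity in this test. The leaving and entering groups hold equal heavy-atom counts, so this step comes without a change in that count. Compound 2 remains a limit, not a number, and adds no step: the limit of < 100000 nM in this assay, at which 1 of the 3 values shown sits.

The change removes both chlorines and adds the methoxy group in one move, so the compounds shown do not separate the two contributions. An unsubstituted benzyl or a 4-chlorobenzyl group in the same place would divide the step into its parts.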